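The compounds below may be only part of what the source reports. "The series", "measured", "known", "first", "only" and "open" are said of these compounds alone.

Of the compounds shown here, two built on one shared core have been measured so far. In a functional assay on NCI-H23 cells (Homo sapiens) for cytotoxicity, read by sulforhodamine B assay, with a stated time of 48 h, tested at 1 uM (on this read-out higher numbers stand for a weaker effect at the one concentration tested and lower numbers for a stronger effect), compound 1 `COc1cc(-c2cc(/C=C/C(=O)c3ccc(N)cc3)[nH]n2)cc(OC)c1OC` gives 95%, and in this assay compound 2 `COc1ccc(C(=O)/C=C/c2cc(-c3cc(OC)c(OC)c(OC)c3)n[nH]2)cc1OC` gives 93%. Among the compounds with values here, the single measured step between them, a number 2 percentage points lower from compound 1 to compound 2 (within the scatter), swaps one aryl group for another on the carbonyl carbon and stays within the scatter. Compound 2 thus holds the lowest of the two numbers, though its gap to compound 1 is too small to count as a real difference.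

Compound 3 `COc1ccc(C(=O)/C=C/c2cc(-c3cc(OC)c(OC)c(OC)c3)n[nH]2)cc1` differs from compound 2 by hydrogen in place of methoxy on an aromatic carbon. Within the data shown here, no measured step concerns this kind of change: the only step available, a number 2 percentage points lower from compound 1 to compound 2 (within the scatter), alters a different part of the molecule and produced no movement beyond the scatter. Among the measured compounds shown here, the expectation can therefore rest only on the fact that the one change seen so far left the number essentially where it was. The expected step is no change at the digits printed from compound 2 to compound 3 (within the scatter), meaning no change beyond the scatter. Compound 3 is accordingly estimated at 93%, with a range from 82% to 100%.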

Compound 3, a percentage reported as activity, at one concentration (the size of the read-out at that concentration, not a potency): 95%
The estimate for compound 3 lay 2 percentage points below the measured number, and the stated range covers the measured number.
By their numbers in this assay, from the lowest: compounds 2, 1 and 3 (each within the scatter of the next).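

Taking away one methoxy group, the one ortho to a methoxy group and meta to a large group, turns 3,4-dimethoxyphenyl into 4-methoxyphenyl and gives a number 2 percentage points higher from compound 2 to compound 3 (within the scatter) in this assay, so at this position hydrogen and methoxy cannot be told apart on this read-out. The comparison with the amino compound points the same way, with no change at the digits printed from compound 1 to compound 3 (within the scatter) for methoxy in place of amino on an aromatic carbon, so 4-aminophenyl, 3,4-dimethoxyphenyl and 4-methoxyphenyl now all lie within the scatter of one another, which a single step could not show. Nothing available explains why these changes leave the number in place.

All three compounds give high numbers, which on this read-out stand for a weak effect at the one concentration tested, so these results do not show whether any change on this ring can move the number beyond the scatter. As far as these compounds go, whether a hydroxyl group, a chlorine atom or a longer chain such as ethoxy on this ring would shift the number remains open, as does the effect of changing the other aromatic ring, which stays the same in all three compounds.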